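The compounds below may be only part of what the source reports. "The series", "measured", "known", "first", "only" and "open" are said of these compounds alone.

Compound 1 `O=C1c2c[n+]([O-])c3ccccc3c2C(=O)c2c1c1ccccc1n2Cc1cn([C@H]2C[C@H](O)[C@@H](CO)O2)nn1` gives 120 nM in a functional assay on HCT-116 cells (Homo sapiens) for cytotoxicity, read by MTT assay, with a stated time of 72 h; on this read-out higher numbers stand for weaker inhibition and lower numbers for stronger inhibition.
Compound 2 `O=C1c2c[n+]([O-])c3ccccc3c2C(=O)c2c1c1ccccc1n2Cc1cn(C[C@@H](O)CO)nn1` gives 190 nM in this assay.
Compound 3 `CC1(C)OCC(Cn2cc(Cn3c4c(c5ccccc53)C(=O)c3c[n+]([O-])c5ccccc5c3C4=O)nn2)O1` gives 70 nM in this assay.

Compound 1 sits second highest of the three numbers. Its nearest neighbour is compound 2, with a 1.6-fold higher number from compound 1 to compound 2 (0.20 log units; within the scatter); its furthest is compound 3, with a 1.7-fold lower number from compound 1 to compound 3 (0.23 log units; within the scatter). Between the other two, a 2.7-fold lower number from compound 2 to compound 3 (0.43 log units; beyond the scatter).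

Compound 4 `O=C1c2c[n+]([O-])c3ccccc3c2C(=O)c2c1c1ccccc1n2Cc1cn([C@@H]2C[C@H](O)[C@@H](CO)O2)nn1` is the next step from compound 1: the two compounds have the same atoms and bonds and differ only in configuration as drawn: 1 of 3 stereo elements differ; a stereocentre at a saturated ring carbon is drawn R in compound 1 and S in compound 4. Going by the values given here, none of the measured steps involves a change of configuration; each swaps one group on the aromatic nitrogen for another. Among the compounds with values here, no measured step therefore bears on this change, and no step beyond the scatter is expected in this assay. Compound 4 is estimated at 130 nM, within 60 nM to 300 nM, which means an expected 1.1-fold higher number from compound 1 to compound 4 (0.03 log units; within the scatter).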

Compound 4, half-maximal inhibitory concentration in the HCT-116 assay: 50 nM
Compound 4: middle estimate off by 2.6-fold (0.41 log units), on the high side, and the stated range ends above it.
By their numbers in the HCT-116 assay, from the lowest: compounds 4, 3, 1 and 2 (each within the scatter of the next, the first and the last beyond it).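

In the HCT-116 assay a change of configuration alone, at a saturated ring carbon, gives a 2.4-fold lower number from compound 1 to compound 4 (0.38 log units; beyond the scatter) and so matters here, which the earlier swaps of whole groups could not show; the same group in this configuration gives a 3.8-fold lower number from compound 2 to compound 4 (0.58 log units; beyond the scatter) and a 1.4-fold lower number from compound 3 to compound 4 (0.15 log units; within the scatter) against the other two groups. In a physicochemical assay for solubility, read by HPLC, with a stated time of 24 h (on this read-out lower numbers stand for lower solubility and higher numbers for higher solubility), compound 1 gives > 5000 ug/mL as a limit of the assay. In the physicochemical assay compound 4 gives > 5000 ug/mL as a limit too, and the step cannot be read: the limit of > 5000 ug/mL in the physicochemical assay, at which 2 of the 2 values shown sit. As far as these compounds go, the other two stereo elements remain open, as does what an amine or a carboxylic acid in place of the 4-hydroxy-5-(hydroxymethyl)oxolan-2-yl group would give in the HCT-116 assay on the shared core.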